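From pentyloxy to hexyl on the shared core

This account rests on a few compounds, and the source may have more. Where it says the series, first, only, none or still open, it means among the compounds named here.

In a functional assay on brain (Rattus norvegicus, strain Wistar) for inhibition (a higher number here means a weaker inhibitor, a lower number a stronger inhibitor), compound 1 `Cc1[nH]c(=O)n(C)c1-c1ccc(C(C)(C)C)cc1` gives 8400 nM and compound 2 `CCCCCOc1ccc(-c2c(C)[nH]c(=O)n2C)cc1` gives 4500 nM as its value, so the two stand within the scatter of each other. Compound 3 `CCCCCCc1ccc(-c2c(C)[nH]c(=O)n2C)cc1` departs from compound 2 by one change, hexyl in place of pentyloxy on an aromatic carbon is its full count. Among the compounds with values here, the one measured step, a 1.9-fold lower number from compound 1 to compound 2 (0.27 log units; within the scatter) for pentyloxy in place of tert-butyl on an aromatic carbon, stayed within the scatter, so no step beyond the scatter is expected in this assay here. The expected size is a 1.1-fold lower number from compound 2 to compound 3 (0.05 log units; within the scatter) overall. Compound 3 is estimated at 4000 nM with 1500 nM to 10000 nM as its range.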

Compound 3, half-maximal inhibitory concentration: 9000 nM
Estimate against measurement, compound 3: 2.3-fold (0.35 log units) below; low and high end bracket the measured number.
By their numbers in this assay, from the lowest: compounds 2, 1 and 3 (each within the scatter of the next).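

In this assay, hexyl in place of pentyloxy takes away the one hydrogen-bond acceptor of the group on the aromatic carbon while its heavy-atom count stays the same, and this gives a 2.0-fold higher number from compound 2 to compound 3 (0.30 log units; within the scatter) and so stays within the scatter. Hexyl in place of tert-butyl gives a 1.1-fold higher number from compound 1 to compound 3 (0.03 log units; within the scatter) and is also within the scatter, so none of the three groups stands apart from the others at this position. Nothing at hand accounts for these numbers.

Going by these compounds, it remains open whether a longer chain, a terminal amine or a carboxylic acid at this position would move the number beyond the scatter.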